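Swapping methoxy for fluoro on a second core

The source may report more compounds than this note shows. Statements on the series, on what has been measured and on what is new or still open speak of the compounds shown alone.

Compound 1, `COc1ccc(/C=C/C(=O)OC[C@@H](OCc2ccccc2)[C@H]2OC(=O)C=C[C@H]2OCc2ccccc2)cc1`, is measured in a functional assay on HeLa cells (Homo sapiens) for antiproliferative activity, read by MTT assay, with a stated time of 6 days (on this read-out higher numbers stand for weaker inhibition and lower numbers for stronger inhibition), and gives 1080 nM. Compound 2, `O=C1C=C[C@@H](OCc2ccccc2)[C@@H]([C@@H](COC(=O)/C=C/c2ccc(F)cc2)OCc2ccccc2)O1`, differs from it in one place: fluoro in place of methoxy on an aromatic carbon. In this assay compound 2 gives 7310 nM, so that this single exchange made a 6.8-fold higher number from compound 1 to compound 2 (0.83 log units; beyond the scatter).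

Compound 3, `COc1ccc(/C=C/C(=O)OC[C@@H](OC(C)=O)[C@H]2OC(=O)C=C[C@H]2OC(C)=O)cc1`, carries the same methoxy-bearing side chain as compound 1 but sits on a different core; the difference between the two cores is not broken down here. In this assay compound 3 gives 5930 nM, a number that lies beyond the scatter from compound 1 and within it from compound 2.

Compound 4, `CC(=O)O[C@@H]1C=CC(=O)O[C@@H]1[C@@H](COC(=O)/C=C/c1ccc(F)cc1)OC(C)=O`, is the fluoro counterpart of compound 3: fluoro in place of methoxy on an aromatic carbon. The place of the change is described in the same words for both pairs, so this is the same change made on a different core. For the measured compounds named here, the only guide to its size is the one earlier example, where the step from compound 1 to compound 2 came out as a 6.8-fold higher number from compound 1 to compound 2 (0.83 log units; beyond the scatter). Taking that step as the best available measure, and allowing that a different core may not carry it over in full, compound 4 is expected to give an estimated 30000 nM in this assay, somewhere between 10000 nM and 90000 nM, which would mean an expected step of a 5.1-fold higher number from compound 3 to compound 4 (0.70 log units; beyond the scatter).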

Compound 4, half-maximal inhibitory concentration: 1680 nM
Compound 4: the middle estimate sits 18-fold (1.25 log units) above what was measured; the whole stated range lies above it.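

In this assay, the exchange of methoxy for fluoro on the second core gives a 3.5-fold lower number from compound 3 to compound 4 (0.55 log units; beyond the scatter), so the number falls here, whereas it rose on the first core. The two steps run in opposite directions, and the gap between them lies beyond what repeated measurements would be expected to scatter, so the size and direction of this exchange did not carry over from one core to the other: the same change on two cores in this assay, a 6.8-fold higher number (0.83 log units; beyond the scatter) from compound 1 to compound 2 and a 3.5-fold lower number (0.55 log units; beyond the scatter) from compound 3 to compound 4, 24-fold (1.38 log units) apart, beyond the scatter of two such steps

For the compounds shown here, this shows that, within these four compounds, the outcome of the exchange depends on the core that carries it, so a step measured on one core is a poor guide to the other; with only two pairs, however, it does not show which part of the cores is responsible or why, and it offers no rule for any further core.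

The compounds shown carry only methoxy and fluoro at this place on the aromatic ring, so it stays open whether another group there, such as chloro, a nitrile or an amine, would also behave differently on the two cores. On these data alone, it also stays open how the exchange would behave on a third core, for instance one bearing a carboxylic acid or a longer chain.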